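A few compounds are considered here, and "the series" means these few. Any claim that something is new, unique, unknown or untested is made for them only; others in the source may bear on it.

In a functional assay on SW480 cells (Homo sapiens) for antiproliferative activity, read by MTT assay, with a stated time of 48 h (a lower number here means a stronger inhibitor, a higher number a weaker inhibitor), the measured compounds are:
compound 1 `CC(C)=CCC[C@]1(C)/C=C/[C@@H](OC(=O)C=C(C)C)[C@](C)(O)/C=C/C(=O)/C(CN(C)C)=C\C1` with 480 nM
compound 2 `CCN(CC)C/C1=C/C[C@](C)(CCC=C(C)C)/C=C/[C@@H](OC(=O)C=C(C)C)[C@](C)(O)/C=C/C1=O` with 270 nM
compound 3 `CC(C)=CCC[C@]1(C)/C=C/[C@@H](OC(=O)C=C(C)C)[C@](C)(O)/C=C/C(=O)/C(CN=[N+]=[N-])=C\C1` with 4230 nM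

Compound 3 has the highest number of the three and is the weakest inhibitor here. Compound 4 `CC(C)=CCC[C@]1(C)/C=C/[C@@H](OC(=O)C=C(C)C)[C@](C)(O)/C=C/C(=O)/C(Cn2cc(CO)nn2)=C\C1` keeps the shared core, and its difference from compound 3 is 4-(hydroxymethyl)-1H-1,2,3-triazol-1-yl in place of azido on a saturated chain carbon bound to a double-bonded ring carbon. The steps of an 8.8-fold higher number from compound 1 to compound 3 (0.95 log units; beyond the scatter) and a 16-fold higher number from compound 2 to compound 3 (1.19 log units; beyond the scatter) at this same place lie beyond the scatter, while a 1.8-fold lower number from compound 1 to compound 2 (0.25 log units; within the scatter) stays within it. Among the measured compounds shown here, these steps show that a change at this place can move the number, but no measured compound carries a triazole, so they give no firm direction. No step beyond the scatter is therefore expected, and the expected change is a 1.4-fold lower number from compound 3 to compound 4 (0.15 log units; within the scatter). For compound 4 the estimated value is 3000 nM with an expected range from 700 nM to 11000 nM.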

Compound 4, half-maximal inhibitory concentration: 2870 nM
Compound 4: the middle estimate sits 1.0-fold (0.02 log units) above what was measured; the range from low to high includes it.
By their numbers in this assay, from the lowest: compounds 2 and 1 (each within the scatter of the next); then compounds 4 and 3 (each within the scatter of the next).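

In this assay, 4-(hydroxymethyl)-1H-1,2,3-triazol-1-yl in place of azido gives a 1.5-fold lower number from compound 3 to compound 4 (0.17 log units; within the scatter), so the added five-membered aromatic ring leaves the number within the scatter. Both amines keep their lead over the triazole, with a 6.0-fold higher number from compound 1 to compound 4 (0.78 log units; beyond the scatter) and an 11-fold higher number from compound 2 to compound 4 (1.03 log units; beyond the scatter), so at this position compound 3 and compound 4, which lack an amine, both sit on the weaker side. No measurement here explains this result.

Open, on these data alone, is whether a morpholine ring on this chain carbon, or a triazole carrying a dimethylaminomethyl group instead of hydroxymethyl, would match compound 2.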